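A few compounds are considered here, and "the series" means these few. Any claim that something is new, unique, unknown or untested is made for them only; others in the source may bear on it.

Measured in a functional assay on SK-OV-3 cells (Homo sapiens) for antiproliferative activity, read by sulforhodamine B assay, with a stated time of 72 h; on this read-out lower numbers stand for stronger inhibition and higher numbers for weaker inhibition:
- compound 1 `S=C(NNc1nncc2ccccc12)Nc1ccccc1`: 0.6 nM
- compound 2 `COc1ccc(NC(=S)NNc2nncc3ccccc23)cc1`: 0.8 nM

Only these two compounds have been measured, and the value of compound 1 lies within the scatter of the value of compound 2, so neither can be ranked above the other. The next compound is compound 3 `NC(=S)NNc1nncc2ccccc12`, which departs from compound 1 as follows: hydrogen in place of phenyl on an amide-type nitrogen. In words, this is hydrogen in place of phenyl on an amide-type nitrogen, or anilino to amino.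

Among the measured compounds shown here, one measured step bears on this: a 1.3-fold higher number from compound 1 to compound 2 (0.12 log units; within the scatter), with methoxy in place of hydrogen on an aromatic carbon. That step is small, but it leaves the phenyl in place, so no measurement shows what losing the whole group does. Both measured compounds keep the phenyl, and compound 3 would be the first without it. A step to a higher number in this assay is therefore expected, though its size is poorly constrained. The expected change is a 10-fold higher number from compound 1 to compound 3 (1.00 log units; beyond the scatter). For compound 3 the estimated value is 6 nM, with an expected range from 0.8 nM to 60 nM.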

Compound 3, half-maximal inhibitory concentration: 0.8 nM
For compound 3 the middle estimate is 7.5-fold (0.88 log units) above the measured one, within the range that was stated.
By their numbers in this assay, from the lowest: compounds 1, 2 and 3 (each within the scatter of the next).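

In this assay, the change of anilino to amino gives a 1.3-fold higher number from compound 1 to compound 3 (0.12 log units; within the scatter), with hydrogen in place of phenyl on an amide-type nitrogen whose other neighbour is the thiocarbonyl carbon. The earlier step altered only a substituent on the phenyl, whereas this one removes all of the phenyl, and the value still stays within the scatter, so in this pair the phenyl on this nitrogen is not required for a value at the level of compound 1. No measurement shown here offers an explanation for this result.

Going by these compounds, it remains open whether this tolerance extends to other groups on the same nitrogen, such as a methyl, a longer alkyl chain, a benzyl or a chain ending in a carboxylic acid, since only hydrogen, phenyl and methoxy-substituted phenyl appear there. The compounds shown also leave open whether the same change would read the same way on a different core, because compound 1 and compound 3 share one core and a single cell-based read-out.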